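Extending the Aromatic Alkyl Chain: Compound 3 to Compound 4

The source may report more compounds than this note shows. Statements on the series, on what has been measured and on what is new or still open speak of the compounds shown alone.

Compound 3 `CCc1ccc(N/N=C2\CCC(C)n3c2ncc(C(=O)O)c3=O)cc1` carries an ethyl group on its aromatic ring. In a functional assay on the whole organism for inhibition, with Rattus norvegicus as the target (on this read-out lower numbers stand for an effect already at smaller amounts and higher numbers for an effect only at larger amounts of compound), compound 3 gives only the limit > 1000 umol/kg. Compound 1 `CC1CC/C(=N\Nc2ccc(Br)cc2)c2ncc(C(=O)O)c(=O)n21` likewise returns the limit > 1000 umol/kg. Compound 2 `Cc1ccc(N/N=C2\CCC(C)n3c2ncc(C(=O)O)c3=O)cc1` also returns the limit > 1000 umol/kg. The steps a step that the two limits leave unreadable from compound 1 to compound 2, a step that the two limits leave unreadable from compound 1 to compound 3 and a step that the two limits leave unreadable from compound 2 to compound 3 therefore have no readable size, since (the limit of > 1000 umol/kg in this assay, at which 3 of the 3 values shown sit). Compound 4 `CCCCc1ccc(N/N=C2\CCC(C)n3c2ncc(C(=O)O)c3=O)cc1` differs from compound 3 by ethyl in place of hydrogen on a saturated chain carbon, two bonds along the chain from an aromatic carbon. The closest measured step, a step that the two limits leave unreadable from compound 2 to compound 3, also lengthens this same chain and gives no direction to build on. Compound 4 is therefore expected to sit near 1500 umol/kg, with a range from 500 umol/kg to 5000 umol/kg, most likely again as a limit. The step estimated from compound 3 onward, a step that the limit leaves unreadable from compound 3 to compound 4, is expected to stay within the scatter.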

Compound 4, dose for 50% inhibition: 100 umol/kg
Beside the measured number, compound 4's estimate is 15-fold (1.18 log units) above it; measured number below the stated range.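

In this assay, among these compounds, butyl on the aromatic carbon gives the first readable change at this position, an at least 10-fold lower number from compound 3 to compound 4 (1.00 log units; beyond the scatter). The same holds against methyl, an at least 10-fold lower number from compound 2 to compound 4 (1.00 log units; beyond the scatter), and against bromo, an at least 10-fold lower number from compound 1 to compound 4 (1.00 log units; beyond the scatter). The steps among compound 1, compound 2 and compound 3 cannot be read: the limit of > 1000 umol/kg in this assay, at which 3 of the 4 values shown sit.

On these data alone, the readable effect rests on compound 4 alone, and its full size stays unknown. As far as these compounds go, whether a longer chain such as hexyl, or a butyl chain ending in an amine, keeps or changes this result remains open.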